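Thiazolidinone amides: replacing the aryl on the ring nitrogen

The source may hold more compounds than are shown below. What is called first, only, known or untested is meant among the compounds shown, and "the series" means these compounds.

Three members of the series have numbers in an ADME assay on microsomes from liver (Rattus norvegicus) for metabolic stability, read by LC-MS, using NADPH, with a stated time of 10 min, tested at 0.1 uM; on this read-out higher numbers stand for fast clearance and lower numbers for slow clearance. Compound 1 `O=C(NCCCCc1ccccc1)c1cccc(C2SCC(=O)N2c2cccc(-c3c[nH]nn3)c2)c1` gives 742 mL.min-1.g-1. Compound 2 `COc1ccccc1N1C(=O)C(C)SC1c1cccc(C(=O)NCCCCc2ccccc2)c1` gives 2910 mL.min-1.g-1. Compound 3 `COc1ccc(F)cc1N1C(=O)CSC1c1cccc(C(=O)NCCCCn2cccn2)c1` gives 1470 mL.min-1.g-1, which sits between the other two, and its gap to compound 2 as well as its gap to compound 1 stays within the usual scatter; no ranking among the three is therefore claimed. Compound 4 `Cc1ccnc(N2C(=O)CSC2c2cccc(C(=O)NCCCCn3cccn3)c2)c1` has not yet been measured in this assay. It differs from compound 3 in one place: 4-methylpyridin-2-yl in place of 5-fluoro-2-methoxyphenyl on an amide-type nitrogen in a ring. Going by the values given here, no measured pair shares this change, so the step is not anchored. A small step, not clearly beyond the scatter, is expected; compound 4 is estimated at 900 mL.min-1.g-1 within 400 mL.min-1.g-1 to 2200 mL.min-1.g-1, meaning an expected step of a 1.6-fold lower number from compound 3 to compound 4 (0.21 log units; within the scatter).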

Compound 4, intrinsic clearance in microsomes: 1020 mL.min-1.g-1
Compound 4: the middle estimate sits 1.1-fold (0.05 log units) below what was measured; measured number inside the range.
By their numbers in this assay, from the lowest: compounds 1, 4, 3 and 2 (each within the scatter of the next, the first and the last beyond it).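

Putting 4-methylpyridin-2-yl in place of 5-fluoro-2-methoxyphenyl on the amide-type nitrogen in a ring gives, in this assay, a 1.4-fold lower number from compound 3 to compound 4 (0.16 log units; within the scatter). This first single-place step in the series shows that, at this position, an aromatic ring with one hetero atom and fewer heavy atoms can replace the all-carbon aryl without a step beyond the scatter. Nothing measured on these compounds accounts for the step.

On these data alone, whether the same swap gives a similar step on the amide chain of compound 1 remains open. So does how a non-aromatic group, such as a morpholine or a piperidine, would read at this nitrogen.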